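This account rests on a few compounds, and the source may have more. Where it says the series, first, only, none or still open, it means among the compounds named here.

Measured compounds in an ADME assay on J774.1 cells (Mus musculus) for cytotoxicity, with a stated time of 48 h; a higher number here means that more compound is needed for the effect, a lower number that less compound is needed:
- compound 1 `COC(=O)C1=C(O)C[C@H](c2ccccn2)N(Cc2ccc(Cl)cc2)[C@@H]1c1ccccn1`: 32.8 uM
- compound 2 `COC(=O)C1C(=O)C(C(=O)OC)[C@H](c2cccc([N+](=O)[O-])c2)N(Cc2ccccc2)[C@@H]1c1cccc([N+](=O)[O-])c1`: the assay reports only a limit, > 100 uM
- compound 3 `C[C@@H]1CC2(C[C@H](C)N1)C(=O)N(CCO)C(=O)N2Cc1ccccc1`: the assay reports only a limit, > 100 uM

Among the compounds with values here, compound 1 stands as the only full number in this assay; the other two values are limits rather than numbers, as the limit of > 100 uM in this assay, at which 2 of the 3 values shown sit, shows. Within the data shown here, no pair of measured compounds differs in a single place, so no measured step is available to calibrate against.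

Compound 4 `COC(=O)C1=C(O)C[C@H](c2ccccn2)N(Cc2cccc(OC)c2)[C@@H]1c1ccccn1` is not yet measured in this assay. It differs from compound 1 by 3-methoxyphenyl in place of 4-chlorophenyl on a saturated chain carbon bound to an amine nitrogen in a ring. Among the measured compounds shown here, with no measured step of this kind to draw on, the expectation for the step from compound 1 to compound 4 is modest, with the number for compound 4 estimated a little higher than that of compound 1, and a real chance that the assay again reports only a limit. The step from compound 1 to compound 4 is expected to be a 1.4-fold higher number from compound 1 to compound 4 (0.14 log units; within the scatter). Compound 4 is estimated at 45 uM, in the range 18 uM to 110 uM.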

Compound 4, concentration for half-maximal effect: > 100 uM
Compound 4 was reported as a limit; the forecaster's own chance of this, stated with the estimate: 25%; middle value at least 2.2-fold (0.34 log units) away from the limit.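

Within the data shown here, the benzyl group on the ring nitrogen is not a silent place in this assay: going from 4-chlorobenzyl to 3-methoxybenzyl gives an at least 3.0-fold higher number from compound 1 to compound 4 (0.48 log units; beyond the scatter), the first measured single-place step. Compound 4 gives > 100 uM, which is a limit of the assay and not a number, so this step has a lower bound only. With compound 4 added, compound 1 remains the only compound in the set with a full number, and most of the set sits at one ceiling: the limit of > 100 uM in this assay, at which 3 of the 4 values shown sit.

The step changes the substituent and its ring position together, and 3-chlorobenzyl or 4-methoxybenzyl at this place would separate the two. On these data alone, whether an amine or a carboxylic acid in place of the 4-chlorobenzyl group would shift the number of compound 1 also stays open.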